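Adding a Methyl to the Acetate-Bearing Chain

The source may report more compounds than this note shows. Statements on the series, on what has been measured and on what is new or still open speak of the compounds shown alone.

Going by the values given here, compound 2 `COc1ccc(C(=O)/C(=C/c2c(F)c(F)c(F)c(F)c2F)CCOC(C)=O)cc1` is the only compound with a numeric result in a functional assay on NB-4 cells (Homo sapiens) for inhibition, read by XTT assay, with a stated time of 48 h (on this read-out higher numbers stand for weaker inhibition and lower numbers for stronger inhibition), where compound 2 gives 28500 nM. Compound 1 `COc1ccc(C(=O)/C(=C/c2ccccc2F)CCOC(C)=O)cc1` reaches only the limit of this assay; in this assay compound 1 gives > 100000 nM. Compound 3 `COc1ccc(C(=O)/C(=C/c2c(F)c(F)c(F)c(F)c2F)CC(C)OC(C)=O)cc1` differs from compound 2 by methyl in place of hydrogen on a saturated chain carbon bound to an oxygen next to a carbonyl group and a saturated chain carbon. Among the compounds with values here, with no measured step of this kind available for comparison, the change is expected to stay within the usual scatter, so a 1.1-fold lower number from compound 2 to compound 3 (0.06 log units; within the scatter) is the estimated step. Compound 3 is therefore expected to give about 25000 nM in this assay, most likely between 8000 nM and 80000 nM.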

Compound 3, half-maximal inhibitory concentration: 49000 nM
Compound 3: the middle estimate sits 2.0-fold (0.29 log units) below what was measured, within the range that was stated.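

Turning 2-acetoxyethyl into 2-acetoxypropyl gives a 1.7-fold higher number from compound 2 to compound 3 (0.24 log units; within the scatter) in this assay. Going by these compounds alone, this is the first measured step at this position, and it shows that one added methyl on this chain carbon leaves the result indistinguishable from that of the unbranched chain. Nothing measured here bears on the size of this step. Going by these compounds, what an ethyl group, an amine or a carboxylic acid would do on this same carbon stays open. So does whether this step holds with a core carrying a different fluorine pattern.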